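Phenylethenyl in place of methoxyphenyl: notes toward compound 4

The source may hold more compounds than are shown below. What is called first, only, known or untested is meant among the compounds shown, and "the series" means these compounds.

Measured so far:
compound 1 `CC(=O)c1cc(-c2ccccc2)cc2cc(-c3ccc(F)cc3)[nH]c12` — 73.3%
compound 2 `COc1ccc(-c2cc(C(C)=O)c3[nH]c(-c4ccc(F)cc4)cc3c2)cc1` — 14.8%
compound 3 `COc1ccc(-c2cc(C(C)=O)c3[nH]c(-c4ccc(OC)cc4)cc3c2)cc1` — 39.9%

In a functional assay on MCF7 cells (Homo sapiens) for cytotoxicity, read by MTT assay, with a stated time of 2 days, tested at 100 uM (on this read-out lower numbers stand for a stronger effect and higher numbers for a weaker effect at the one concentration tested), compound 2 gives 14.8%, the lowest of the three numbers. Compound 3 gives 39.9% and compound 1 gives 73.3%, each of them beyond the scatter from compound 2. Compound 4 `CC(=O)c1cc(/C=C/c2ccccc2)cc2cc(-c3ccc(F)cc3)[nH]c12` differs from compound 2 in one place: 2-phenylethenyl in place of 4-methoxyphenyl on an aromatic carbon.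

Within the data shown here, two measured steps bear on this change. The first is a number 58.5 percentage points lower from compound 1 to compound 2 (beyond the scatter), a large step in which a methoxy group arrived on the pendant ring. The second is a number 25.1 percentage points higher from compound 2 to compound 3 (beyond the scatter), a modest step. Compound 4, like compound 1, carries no methoxy group on the group that enters, and the expectation is therefore that compound 4 gives up part of the effect seen for compound 2 because a number 58.5 percentage points lower from compound 1 to compound 2 (beyond the scatter) ties the methoxy group's arrival to the large downward step. The entering group is not a plain phenyl, so the return toward compound 1 is expected to be incomplete. Compound 4 is expected at 50%, with a range of 22% to 85%. That estimate means a step of a number 35.2 percentage points higher from compound 2 to compound 4 (beyond the scatter) is expected.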

Compound 4, a percentage reported as activity, at one concentration (the size of the read-out at that concentration, not a potency): 50.1%
Compound 4: the middle estimate sits 0.1 percentage points below what was measured; the range from low to high includes it.
By their numbers in this assay, from the lowest: compound 2; then compound 3; then compound 4; then compound 1.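

Against plain phenyl, this assay shows a number 23.2 percentage points lower from compound 1 to compound 4 (beyond the scatter) at this position, so a methoxy group on the entering group is not needed for some lowering of the number. Against 4-methoxyphenyl, the same assay shows a number 35.3 percentage points higher from compound 2 to compound 4 (beyond the scatter) even though both groups hold the same count of heavy atoms and one aromatic ring of carbon only, so the position tells them apart on more than size by that count. No measurement bearing on the cause of either step is at hand.

The compounds shown do not separate the effect of the double bond from that of the phenyl ring's placement at the end of the group. From the compounds shown here alone, a saturated 2-phenylethyl chain, or a 4-hydroxyphenyl or 4-aminophenyl group at this position, remains open.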